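The source may hold more compounds than are shown below. What is called first, only, known or untested is meant among the compounds shown, and "the series" means these compounds.

Compound 1 `COc1ccc(C(=O)/C=C/c2cc(-c3cc(OC)c(OC)c(OC)c3)n3nc(-c4ccccc4)cc3n2)cc1` — 79800 nM
Compound 2 `COc1cc(-c2cc(C(=O)/C=C/c3ccc(Cl)cc3)nc3cc(-c4ccccc4)nn23)cc(OC)c1OC` — 53900 nM
Compound 3 `COc1cc(-c2cc(/C=C/C(=O)c3ccccc3)nc3cc(-c4ccccc4)nn23)cc(OC)c1OC` — >= 100000 nM

All three were run in an ADME assay on HEK293 cells (Homo sapiens) for antiproliferative activity, read by MTT assay, with a stated time of 24 h; a higher number here means a weaker inhibitor, a lower number a stronger inhibitor. Compound 1 holds the higher of the two plain numbers, and compound 2 stands nearest to it, the step being a 1.5-fold lower number from compound 1 to compound 2 (0.17 log units; within the scatter). For compound 3 the assay reports only a limit, namely (the limit of >= 100000 nM in this assay, at which 1 of the 3 values shown sits), and not a number. The steps of an at least 1.2-fold higher number from compound 1 to compound 3 (0.09 log units; that floor lies within the scatter) and an at least 1.8-fold higher number from compound 2 to compound 3 (0.26 log units; that floor lies within the scatter) accordingly carry floors that sit within the scatter, so the three measured compounds spread over no more than the usual repeat range.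

Compound 4 `COc1ccc(C(=O)/C=C/c2cc(-c3ccc(OC)cc3)n3nc(-c4ccccc4)cc3n2)cc1` has not yet been measured in this assay. It differs from compound 1 by 4-methoxyphenyl in place of 3,4,5-trimethoxyphenyl on an aromatic carbon. For the measured compounds named here, none of the measured steps touches this position: each of them concerns the other aromatic ring or the chain that joins it to the core, and each of them stayed within the scatter. Going by the values given here, with no step at this position to lean on, and the measured values so close together, the step of a 1.0-fold higher number from compound 1 to compound 4 (0.00 log units; within the scatter) is expected to be none beyond the scatter. Compound 4 is therefore expected to give 80000 nM in this assay, with a range from 35000 nM to 200000 nM, and a sizeable chance that only a limit is returned.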

Compound 4, half-maximal inhibitory concentration: 36100 nM
Compound 4: the middle estimate sits 2.2-fold (0.35 log units) above what was measured; the measured number falls inside the stated range.
By their numbers in this assay, from the lowest: compounds 4, 2 and 1 (each within the scatter of the next, the first and the last beyond it). At a limit, above all of these: compound 3.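

In this assay, putting 4-methoxyphenyl in place of 3,4,5-trimethoxyphenyl on the aromatic carbon next to the ring nitrogen gives a 2.2-fold lower number from compound 1 to compound 4 (0.34 log units; beyond the scatter) and is the only step shown that passes beyond the scatter, though modestly. For the compounds shown here, this position therefore registers in the read-out, whereas none of the earlier steps, all of which concern the other aromatic ring or the chain joining it to the core, was printed as beyond the scatter. The one line of supporting data concerns the limit of another compound and does not bear on this step.

With only these two groups shown at this position, it remains open whether an unsubstituted phenyl, or a phenyl carrying a hydroxy group, an amine or a carboxylic acid, would give a lower or a higher number than 4-methoxyphenyl. Going by these compounds alone, it is also open whether 4-methoxyphenyl would give a step of similar size with the chain of compound 2 or compound 3 in place of the one carried by compound 1.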